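A few compounds are considered here, and "the series" means these few. Any claim that something is new, unique, unknown or untested is made for them only; others in the source may bear on it.

Compound 1 `C=C1C[C@]23C[C@@]1(O)CC[C@H]2c1ccc(OS(=O)(=O)c2ccc(C)cc2)c(C)c1[C@@H]3Cn1cc(-c2ccc(Br)cc2)nn1` was examined in a functional assay on SMMC-7721 cells (Homo sapiens) for cytotoxicity, read by MTT assay, with a stated time of 4 days; on this read-out lower numbers stand for stronger inhibition and higher numbers for weaker inhibition. In this assay compound 1 gives only a limit, > 20000 nM. Compound 2 `Cc1c(O)ccc2c1[C@H](Cn1cc(-c3ccccn3)nn1)[C@@]13CC(=O)[C@@](C)(CC[C@@H]21)C3` is the other compound measured. In this assay compound 2 likewise gives only a limit, > 20000 nM. Both values shown thus sit at the limit of > 20000 nM in this assay, at which 2 of the 2 values shown sit, so compound 1 cannot be ranked against compound 2. Compound 3 `C=C1C[C@]23C[C@@]1(O)CC[C@H]2c1ccc(OS(=O)(=O)c2ccc(C)cc2)c(C)c1[C@@H]3Cn1cc(-c2ccc(C)cc2)nn1` differs from compound 1 by methyl in place of bromo on an aromatic carbon. For the measured compounds named here, with no measured step to lean on, the expected step that the limit leaves unreadable from compound 1 to compound 3 is none beyond the usual scatter. Compound 3 is therefore expected to give about 30000 nM, within a range from 15000 nM to 100000 nM, most likely again only as a limit.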

Compound 3, half-maximal inhibitory concentration: > 20000 nM
Compound 3: only a limit was reported; the forecaster's own chance of this, stated with the estimate: 85%; the middle value lies beyond the limit too.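

No step can be read from compound 1 to compound 3, as each gives only a limit: the limit of > 20000 nM in this assay, at which 3 of the 3 values shown sit. The compounds shown leave open whether methyl in place of bromo on an aromatic carbon alters the result in this assay at all.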